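Bromocatechol benzyl ethers: extending the alkoxy chain

The source may report more compounds than this note shows. Statements on the series, on what has been measured and on what is new or still open speak of the compounds shown alone.

Working notes on a small set of brominated catechols carrying an ether-linked side chain, tested in a functional assay on HCT-116 cells (Homo sapiens) for cytotoxicity, read by MTT assay, with a stated time of 96 h; a lower number here means a stronger inhibitor, a higher number a weaker inhibitor. In this assay compound 1 `O=Cc1cc(O)c(O)c(Br)c1Br` gives "not determined" (no result reported), and compound 2 `COCc1cc(O)c(O)c(Br)c1` gives "not determined" (no result reported), so neither has a reported result. Among the measured compounds shown here, compound 3 `COCc1cc(Br)c(O)c(O)c1Br` is the one member with a number: in this assay compound 3 gives 3480 nM, and since it is the only value shown, it cannot be placed against any other member of the series.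

The next step leads to compound 4 `CCCOCc1cc(Br)c(O)c(O)c1Br`. The change from compound 3 to compound 4 is ethyl in place of hydrogen on a saturated chain carbon bound to an oxygen on a saturated carbon, so the methoxymethyl becomes a propoxymethyl while the dibrominated catechol core is untouched. For the measured compounds named here, no measured pair illustrates a step of this kind here, so there is no basis for a direction beyond the scatter. A change of this size is expected to move the value only modestly, if at all; in this assay the step from compound 3 to compound 4 is estimated as a 1.4-fold lower number from compound 3 to compound 4 (0.14 log units; within the scatter), close to the scatter. Compound 4 is therefore expected to give 2500 nM in this assay, with a likely range from 800 nM to 8000 nM.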

Compound 4, half-maximal inhibitory concentration: 800 nM
The estimate for compound 4 lay 3.1-fold (0.49 log units) above the measured number; the range from low to high includes it.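

Extending the methoxymethyl to the propoxymethyl, with the shared core untouched, gives in this assay a 4.4-fold lower number from compound 3 to compound 4 (0.64 log units; beyond the scatter) and this step lies beyond the usual scatter. Among the compounds shown here, the single value for compound 3 could not show that this side chain matters; the ethyl in place of hydrogen on a saturated chain carbon bound to an oxygen on a saturated carbon now shows that the number responds to a change at this position. No available measurement bears on what lies behind the shift.

From the compounds shown here alone, one step does not make a trend, and whether a longer chain such as butoxymethyl would lower the number further remains open. Also open, going by these compounds, is how an amine or a carboxylic acid at the end of the ether chain would read in this assay.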